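The source may hold more compounds than are shown below. What is called first, only, known or untested is meant among the compounds shown, and "the series" means these compounds.

Compound 1, `C#Cc1cccc(Nc2ncnn3ccc(CN4CCC(N)CC4)c23)c1`: 2300 nM.
Compound 2, `NC1CCN(Cc2ccn3ncnc(Nc4cccc(F)c4)c23)CC1`: a limit, > 5000 nM.

For the measured compounds named here, in a functional assay on A2780 cells (Homo sapiens) for antiproliferative activity (a lower number here means a stronger inhibitor, a higher number a weaker inhibitor), compound 1 gives 2300 nM, the only plain number among the two measured compounds. For compound 2 the assay reports only a limit, > 5000 nM, not a number. Going by the values given here, the one measured step, an at least 2.1-fold higher number from compound 1 to compound 2 (0.33 log units; beyond the scatter), weakened inhibition, its full size hidden by the limit of > 5000 nM in this assay, at which 1 of the 2 values shown sits. Compound 3 `NC1CCN(Cc2ccn3ncnc(Nc4cccc(Br)c4)c23)CC1` differs from compound 1 by bromo in place of ethynyl on an aromatic carbon, the same kind of change. A weakening of comparable size is expected, a 1.5-fold higher number from compound 1 to compound 3 (0.18 log units; within the scatter). Compound 3 is therefore estimated at 3500 nM, between 1500 nM and 9000 nM.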

Compound 3, half-maximal inhibitory concentration: 2600 nM
Estimate against measurement, compound 3: 1.3-fold (0.13 log units) above; the measured number falls inside the stated range.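

Putting bromo in place of ethynyl gives a 1.1-fold higher number from compound 1 to compound 3 (0.05 log units; within the scatter), so compound 1 and compound 3 cannot be told apart, and the ethynyl group can be replaced here without a measurable loss. Going from fluoro to bromo gives an at least 1.9-fold lower number from compound 2 to compound 3 (0.28 log units; that floor lies within the scatter), so even this floor does not show a real difference. Compound 2 has only a limit, which hides the true size of that step: the limit of > 5000 nM in this assay, at which 1 of the 3 values shown sits.

On these data alone, it remains open whether chloro, methoxy or an amine at this place would match bromo or fall off as fluoro may.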